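The source may report more compounds than this note shows. Statements on the series, on what has been measured and on what is new or still open speak of the compounds shown alone.

Measured so far in a functional assay on HL-60 cells (Homo sapiens) for antiproliferative activity, read by MTT assay, with a stated time of 48 h; a higher number here means a weaker inhibitor, a lower number a stronger inhibitor:

compound 1, `CNC1=C(SC)C(=O)c2ncccc2C1=O`, 3440 nM
compound 2, `CNC1=C(Sc2ccccc2)C(=O)c2ncccc2C1=O`, 8030 nM
compound 3, `CNC1=C(SC)C(=O)c2cccnc2C1=O`, 7920 nM

Compound 1 and compound 2 share one core and differ in a single place: phenyl in place of methyl on a sulfur. The step of a 2.3-fold higher number from compound 1 to compound 2 (0.37 log units; beyond the scatter) made compound 2 the weaker inhibitor of the two. Compound 3 has the same atoms as compound 1, joined differently; the difference between the two cores is not broken down here. Compound 3 and compound 2 lie within the scatter of each other, while compound 3 stands beyond the scatter from compound 1.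

Compound 4, `CNC1=C(Sc2ccccc2)C(=O)c2cccnc2C1=O`, is not yet measured. It differs from compound 3 in one place: phenyl in place of methyl on a sulfur. The surroundings of the place are the same in both pairs, a sulfur whose other neighbour is a double-bonded ring carbon, so this is the same change seen once already. Among the compounds with values here, only that one example exists, so the expectation rests on it alone. Compound 4 is expected to show a 2.1-fold higher number from compound 3 to compound 4 (0.33 log units; beyond the scatter) because the earlier pair gave a 2.3-fold higher number from compound 1 to compound 2 (0.37 log units; beyond the scatter). Compound 4 is therefore estimated at 17000 nM in this assay , probably between 8000 nM and 40000 nM.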

Compound 4, half-maximal inhibitory concentration: 5880 nM
The estimate for compound 4 lay 2.9-fold (0.46 log units) above the measured number, and the stated range ends above it.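

In this assay, putting phenyl in place of methyl on the sulfur gave a 1.3-fold lower number from compound 3 to compound 4 (0.13 log units; within the scatter), so on this core the two groups cannot be told apart. The change therefore does not carry over unchanged from one core to the other, since it weakens compound 1 but leaves compound 3 where it was, and the two steps differ by more than measurement noise: the same change on two cores in this assay, a 2.3-fold higher number (0.37 log units; beyond the scatter) from compound 1 to compound 2 and a 1.3-fold lower number (0.13 log units; within the scatter) from compound 3 to compound 4, 3.1-fold (0.50 log units) apart, beyond the scatter of two such steps This does not show why the two cores respond differently, and two pairs alone cannot say which response would be the more typical for further compounds in this series.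

The compounds shown leave open how a longer chain such as ethyl or a benzyl group on the sulfur would behave on either core, and whether a phenyl carrying a chlorine or a methoxy group would follow the same course. They also leave open what an ethylamine or a plain amine would do in place of the methylamine that all four compounds share.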